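The source may hold more compounds than are shown below. What is called first, only, known or untested is meant among the compounds shown, and "the series" means these compounds.

Measured so far in an ADME assay on microsomes from liver (Rattus norvegicus) for metabolic stability, read by HPLC, using NADPH, with stated times of 5 min and 60 min, tested at 10 uM (on this read-out lower numbers stand for slow clearance and higher numbers for fast clearance), are two compounds:
- compound 1 `CCS(=O)(=O)Nc1ccc(Oc2ccccc2)c(-c2cn(C)c(=O)c3[nH]ccc23)c1` gives 3330 mL/min/kg
- compound 2 `Cn1cc(-c2cc(NS(C)(=O)=O)ccc2Oc2ccccc2C(F)(F)F)c2cc[nH]c2c1=O` gives 250 mL/min/kg

Compound 2, at 250 mL/min/kg in this assay, has the lower of the two numbers, and the gap up to compound 1 lies beyond the usual scatter. For the measured compounds named here, these two compounds do not differ in just one place, so the series offers no measured single-place step to lean on.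

Compound 3 `Cn1cc(-c2cc(NS(C)(=O)=O)ccc2Oc2cccnc2)c2cc[nH]c2c1=O` has not yet been measured. In counts, pyridin-3-yl in place of 2-(trifluoromethyl)phenyl on an oxygen on an aromatic ring is the whole difference from compound 2, with pyridin-3-yl in place of 2-(trifluoromethyl)phenyl on an oxygen on an aromatic ring.

Without a measured precedent, compound 2 at 250 mL/min/kg is the only close reference, so the expectation in this assay is no shift beyond the scatter, with a slight lean towards lower clearance. The expected step is a 1.3-fold lower number from compound 2 to compound 3 (0.10 log units; within the scatter) and it stays within the scatter. Compound 3 is estimated at 200 mL/min/kg (expected range 70 mL/min/kg to 700 mL/min/kg).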

Compound 3, clearance: 350 mL/min/kg
The estimate for compound 3 lay 1.8-fold (0.24 log units) below the measured number, and the stated range covers the measured number.
By their numbers in this assay, from the lowest: compounds 2 and 3 (each within the scatter of the next); then compound 1.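

In this assay, for the compounds shown here, pyridin-3-yl in place of 2-(trifluoromethyl)phenyl on an oxygen on an aromatic ring gives a 1.4-fold higher number from compound 2 to compound 3 (0.15 log units; within the scatter), which is the only measured single-place step so far. This position therefore accepts an exchange of a carbon-only aromatic ring carrying trifluoromethyl for a smaller aromatic ring with one hetero atom and one hydrogen-bond acceptor, and the read-out does not separate the two groups beyond the usual scatter. Nothing at hand accounts for this outcome or ties it to any feature of either group.

The compounds shown leave open whether the same holds for other groups on this oxygen, such as a cyclohexyl ring, a pyridin-2-yl ring or a phenyl ring bearing a carboxylic acid, and whether a step beyond the scatter can be found there at all. Also open, going by these compounds, is how the number for compound 1, at 3330 mL/min/kg, divides among its differences from the other compounds, and a single-place partner for it, such as the ethylsulfonyl group on the core of compound 2, would be needed to read that.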